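Swapping Hydroxy for Amino on a Shared Core

The compounds below may be only part of what the source reports. "The series", "measured", "known", "first", "only" and "open" are said of these compounds alone.

Of the compounds shown here, three built on one shared core have been tested in a functional assay on HT-29 cells (Homo sapiens) for inhibition, read by MTT assay, with a stated time of 2 days; a lower number here means a stronger inhibitor, a higher number a weaker inhibitor. Compound 1 `Oc1cccc(/C=C/c2ccccc2O)c1` gives 27 ug/mL, compound 3 `Nc1ccccc1/C=C/c1ccccc1O` gives 36 ug/mL, and compound 2 `Oc1ccc(/C=C/c2ccccc2O)cc1` gives 22 ug/mL. Compound 2 stands at the lowest of the three numbers, but both others lie within the usual scatter of it, so no order among them can be claimed. Compound 4 `Nc1ccccc1/C=C/c1ccc(O)cc1` has not yet been measured; it differs from compound 2 by amino in place of hydroxy on an aromatic carbon. For the measured compounds named here, no measured pair tests this exchange directly. The values of compound 1, 27 ug/mL, and of compound 3, 36 ug/mL, sit close together. In this assay the change from compound 2 to compound 4 is expected to be small, a 1.4-fold higher number from compound 2 to compound 4 (0.13 log units; within the scatter), with no direction beyond the scatter. Compound 4 is therefore estimated at 30 ug/mL, in a range from 15 ug/mL to 60 ug/mL.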

Compound 4, half-maximal inhibitory concentration: > 100 ug/mL
Compound 4 ended at the assay's limit; the forecaster's own chance of this, stated with the estimate: 5%; at least 3.3-fold (0.52 log units) between middle value and limit.
By their numbers in this assay, from the lowest: compounds 2, 1 and 3 (each within the scatter of the next). At a limit, above all of these: compound 4.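

At this place, on an aromatic carbon ortho to a group of 9 heavy atoms, amino in place of hydroxy gives an at least 4.5-fold higher number from compound 2 to compound 4 (0.65 log units; beyond the scatter), even though the counts of heavy atoms, donors and acceptors stay the same. From the compounds shown here alone, compound 4 stands at a limit of the assay, so the full size of this step remains unknown: the limit of > 100 ug/mL in this assay, at which 1 of the 4 values shown sits. The amino group alone does not settle the outcome, as compound 3 also carries amino and gives 36 ug/mL.

Going by these compounds, whether a methoxy group or a fluorine at this place would behave like hydroxy or like amino stays open.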